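From Aryl Urea to Plain Benzamide on a Shared Core

The compounds below may be only part of what the source reports. "The series", "measured", "known", "first", "only" and "open" are said of these compounds alone.

Compound 3 `COc1cc(-c2nn(-c3cccc(NC(=O)Nc4ccc(Cl)c(C(F)(F)F)c4)c3)cc2-c2ccncc2)ccc1Cl` is one of three measured members of a shared core. In a functional assay on HCT-15 cells (Homo sapiens) for inhibition, read by sulforhodamine B assay, with a stated time of 48 h (on this read-out lower numbers stand for stronger inhibition of growth and higher numbers for weaker inhibition of growth), compound 3 gives 1230 nM, the same number as compound 1 `COc1cc(-c2nn(-c3cccc(NC(=O)Nc4ccc(Cl)c(Cl)c4)c3)cc2-c2ccncc2)ccc1Cl`, which gives 1230 nM; compound 2 `COc1cc(-c2nn(-c3cccc(NC(=O)Nc4cccc(C(F)(F)F)c4)c3)cc2-c2ccncc2)ccc1Cl` gives 870 nM, and a 1.4-fold higher number from compound 2 to compound 3 (0.15 log units; within the scatter). Likewise no change at the digits printed from compound 1 to compound 3 (within the scatter). Compound 4 `COc1cc(-c2nn(-c3cccc(NC(=O)c4ccccc4)c3)cc2-c2ccncc2)ccc1Cl` is the unmeasured member: phenyl in place of (4-chloro-3-(trifluoromethyl)phenyl)amino on a carbonyl carbon. The measured steps only swap groups on the outer ring and keep the urea intact, so none bears directly on this change, which removes far more of the molecule than any of them. Compound 4 is expected to give 3500 nM, in the range 1200 nM to 12000 nM. The estimated step of a 2.8-fold higher number from compound 3 to compound 4 (0.45 log units; beyond the scatter) therefore points toward weaker growth inhibition, with wide uncertainty.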

Compound 4, concentration for 50% growth inhibition: 654 nM
Estimate against measurement, compound 4: 5.4-fold (0.73 log units) above; measured number outside the range, below it.
By their numbers in this assay, from the lowest: compounds 4, 2, 1 and 3 (each within the scatter of the next).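

In this assay the whole substituted (phenyl)amino part of the urea can give way to a plain phenyl on the carbonyl carbon with every step staying within the scatter (a 1.9-fold lower number from compound 3 to compound 4 (0.27 log units; within the scatter)) (a 1.3-fold lower number from compound 2 to compound 4 (0.12 log units; within the scatter)) (a 1.9-fold lower number from compound 1 to compound 4 (0.27 log units; within the scatter)). Across these four compounds, then, neither the amino nitrogen nor the chloro and trifluoromethyl groups are required for this level of growth inhibition. Nothing given here accounts for this result. Open, as far as these compounds go, is whether an amine or a carboxylic acid on the new phenyl, or a plain methyl in its place on the carbonyl carbon, would leave the number where it is.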